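This account rests on a few compounds, and the source may have more. Where it says the series, first, only, none or still open, it means among the compounds named here.

Compounds measured so far:
- compound 1, `CCCCN(CC)c1cc(C)nc2c1NCCN2c1ccc(OC)nc1OC`: 2.2 nM
- compound 2, `CCCCN(CC)c1nc(C)nc2c1NCCN2c1ccc(OC)nc1OC`: 9.9 nM
- compound 3, `CCCCN(CC)c1cc(C)nc2c1NC(=O)CN2c1ccc(C#N)cc1C`: 3.3 nM

All three were run in an assay on frontal cortex for displacement of a labelled ligand from corticotropin-releasing factor receptor 1 (Rattus norvegicus); on this read-out higher numbers stand for weaker inhibition and lower numbers for stronger inhibition. Compound 3 gives 3.3 nM in this assay, the second highest of the three numbers. The number for compound 1, 2.2 nM, lies within the scatter of the number for compound 3, so the two cannot be told apart. Within the data shown here, compound 2, with 9.9 nM, sits beyond the scatter on the higher side; compound 3 and compound 2 differ in the core, not in one place, so no single step is drawn from that pair.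

The next compound, compound 4, `CCCCN(CC)c1cc(C)nc2c1NC(=O)CN2c1ccc(C(C)=O)cc1C`, differs from compound 3 in one place only: acetyl in place of cyano on an aromatic carbon. Among the measured compounds shown here, no measured pair shows this exchange, so the size of the step is not known from the series. Since an acetyl group and a cyano group each bring one hydrogen-bond acceptor and neither adds a ring or a charge, the expected step from compound 3 to compound 4 in this assay is small, a 1.8-fold higher number from compound 3 to compound 4 (0.26 log units; within the scatter), most likely within the scatter and if anything toward a slightly higher number. Compound 4 is therefore estimated at 6 nM in this assay, with a range from 2 nM to 20 nM.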

Compound 4, half-maximal inhibitory concentration: 5.8 nM
Compound 4: middle estimate off by 1.0-fold (0.01 log units), on the high side; measured number inside the range.
By their numbers in this assay, from the lowest: compounds 1, 3, 4 and 2 (each within the scatter of the next, the first and the last beyond it).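

In this assay, acetyl in place of cyano on an aromatic carbon gives a 1.8-fold higher number from compound 3 to compound 4 (0.24 log units; within the scatter), the first exchange read at this place, para to a large group on the six-membered aromatic ring of carbon only. The two groups cannot be told apart here, so going from a triple bond outside aromatic rings to a double bond, and from 2 heavy atoms to 3, leaves the number within the scatter for this one pair. Nothing available bears on why the two groups read alike.

Open, from the compounds shown here alone, is whether a group carrying hydrogen-bond donors, such as an amine or a carboxylic acid, or a longer chain such as a butyryl group at this place would also stay within the scatter of compound 3. Also open, going by these compounds, is whether the same exchange reads alike on the core of compound 1.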